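Dimethylamino in place of isopropylsulfanyl on compound 1

The source may hold more compounds than are shown below. What is called first, only, known or untested is meant among the compounds shown, and "the series" means these compounds.

Measured compounds in an assay for inhibition of MAP kinase-interacting serine/threonine-protein kinase 2 (Homo sapiens), read by TR-FRET; on this read-out higher numbers stand for weaker inhibition and lower numbers for stronger inhibition:
- compound 1, `COc1ccc(Nc2nccc(-c3sc(SC(C)C)nc3C)n2)c(OC)c1`: 1300 nM
- compound 2, `COc1ccc(Nc2nccc(-c3cn(C)c4ccccc34)n2)c(OC)c1`: 610 nM
- compound 3, `COc1ccc(Nc2nccc(-c3cn(C(C)C)c4ccccc34)n2)c(OC)c1`: 220 nM

Compound 1 stands highest of the three numbers; compound 2 is nearest to it, and compound 3 lies furthest away. Compound 4, `COc1ccc(Nc2nccc(-c3sc(N(C)C)nc3C)n2)c(OC)c1`, differs from compound 1 by dimethylamino in place of isopropylsulfanyl on an aromatic carbon. Going by the values given here, the only measured step, a 2.8-fold lower number from compound 2 to compound 3 (0.44 log units; beyond the scatter), changes a group on an aromatic nitrogen in a different part of the shared core and does not bear on the change to compound 4. Among the compounds with values here, no measured pair exchanges one group for another at this position, so no step beyond the scatter is expected in this assay. Compound 4 is therefore estimated at 1300 nM, in the range 450 nM to 3800 nM. The expected step is no change at the digits printed from compound 1 to compound 4 (within the scatter).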

Compound 4, inhibition constant: 200 nM
For compound 4 the middle estimate is 6.5-fold (0.81 log units) above the measured one; measured number below the stated range.
By their numbers in this assay, from the lowest: compounds 4 and 3 (each within the scatter of the next); then compound 2; then compound 1.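

In this assay, going by these compounds alone, dimethylamino in place of isopropylsulfanyl gives a 6.5-fold lower number from compound 1 to compound 4 (0.81 log units; beyond the scatter), showing that the number responds to the group held on this aromatic carbon, which no earlier pair had tested. The step comes with no difference in the counted hydrogen-bond donors or acceptors of the two groups. Nothing shown here gives a measured reason for the step.

The compounds shown leave open whether the lower number follows from the nitrogen attachment or from dimethylamino in particular. A primary amine, morpholine or methylsulfanyl at this place would help separate these possibilities.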